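A few compounds are considered here, and "the series" means these few. Any claim that something is new, unique, unknown or untested is made for them only; others in the source may bear on it.

Working notes on the series, read out in an ADME assay on BJ cells (Homo sapiens) for antiproliferative activity, with a stated time of 72 h; on this read-out lower numbers stand for an effect already at smaller amounts and higher numbers for an effect only at larger amounts of compound. Compound 1 `COc1ccc(-c2[nH]c3cc(OC)cc(OC)c3c(=O)c2I)cc1` shows only a limit of the assay, > 86200 nM, and no number. For the measured compounds named here, compound 2 `COc1ccc(-c2cc(=O)c3c(OC)cc(OC)cc3n2S(=O)(=O)c2ccc([N+](=O)[O-])cc2)cc1` likewise gives only a limit, > 29300 nM, not a number, and so stands at the limit of > 29300 nM in this assay, at which 1 of the 2 values shown sits, with no step between measured compounds to draw on. Compound 3 `COc1ccc(-c2cc(=O)c3c(OC)cc(OC)cc3n2S(=O)(=O)Cc2ccccc2)cc1` is not yet measured and differs from compound 2 by benzyl in place of 4-nitrophenyl on a sulfonyl sulfur. No change beyond the scatter of this assay is expected from that exchange. Compound 3 is therefore expected near 50000 nM, within 15000 nM to 150000 nM. The expected step is a step that the limit leaves unreadable from compound 2 to compound 3, most likely again reported only as a limit.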

Compound 3, half-maximal effective concentration: > 34400 nM
Compound 3: only a limit was reported; the forecaster's own chance of this, stated with the estimate: 75%; the middle value is on the limit's open side.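

Compound 2 and compound 3 are both reported only as limits, so the step between them cannot be read. The compounds shown leave open what actual value any of them would give in this assay, and whether benzyl and 4-nitrophenyl on a sulfonyl sulfur differ at all.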